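This account rests on a few compounds, and the source may have more. Where it says the series, first, only, none or still open, it means among the compounds named here.

Measured so far:
- compound 1, `COC(=O)/C(=C/Cn1c(-c2ccccc2)ncc(NC(=O)OCc2ccccc2)c1=O)COC(=O)c1ccc([N+](=O)[O-])cc1`: in a functional assay on cells (Colon cell line, Homo sapiens) for inhibition (on this read-out higher numbers stand for weaker inhibition and lower numbers for stronger inhibition), compound 1 gives 7.6 ug/mL
- compound 2, `COC(=O)/C(=C/Cn1c(-c2ccccc2)ncc(NC(=O)N2CCN(C(C)=O)CC2)c1=O)COC(C)=O`: in this assay compound 2 gives > 50 ug/mL

The value of compound 2 is a limit of the assay, not a number; it sits at the limit of > 50 ug/mL in this assay, at which 1 of the 2 values shown sits. Compound 3, `COC(=O)/C(=C/Cn1c(-c2ccccc2)ncc(NC(=O)OCc2ccccc2)c1=O)COC(C)=O`, differs from compound 2 by benzyloxy in place of 4-acetylpiperazin-1-yl on a carbonyl carbon. Among the compounds with values here, no step between measured compounds is known, so any expectation rests on compound 1, which carries the same benzyloxy group on that carbonyl carbon and gives 7.6 ug/mL. On that ground compound 3 is expected to gain clearly in inhibition, an at least 5.0-fold lower number from compound 2 to compound 3 (0.69 log units; beyond the scatter), beyond the scatter. Compound 3 is estimated at 10 ug/mL, within 3 ug/mL to 40 ug/mL.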

Compound 3, half-maximal inhibitory concentration: > 50 ug/mL
Compound 3: only a limit was reported; the forecaster's own chance of this, stated with the estimate: 25%; middle value at least 5.0-fold (0.69 log units) from the limit.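

Replacing 4-nitrophenyl with methyl on a carbonyl carbon weakens inhibition in this assay, with an at least 6.5-fold higher number from compound 1 to compound 3 (0.81 log units; beyond the scatter). Compound 1 and compound 3 both carry benzyloxy, so that group alone does not secure the inhibition seen for compound 1. Compound 3 gives a limit of the assay rather than a number, as compound 2 does, so the step between them cannot be read: the limit of > 50 ug/mL in this assay, at which 2 of the 3 values shown sit.

From the compounds shown here alone, whether benzyloxy and 4-acetylpiperazin-1-yl differ at all stays open. Also open, going by these compounds, is whether a plain phenyl or a longer chain such as butyl, in place of 4-nitrophenyl, would bring inhibition back.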